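Pentylamide to Acid: Cytotoxicity in HeLa Cells

The source may report more compounds than this note shows. Statements on the series, on what has been measured and on what is new or still open speak of the compounds shown alone.

Compound 1 `C=CC1=C(C(=O)NCCCCC)C(c2ccc(Cl)c(Cl)c2)OC1` was tested in a functional assay on HeLa cells (Homo sapiens) for cytotoxicity, read by MTT assay, with a stated time of 24 h; on this read-out higher numbers stand for weaker inhibition and lower numbers for stronger inhibition. In this assay compound 1 gives > 100000 nM, which is a limit of the assay and not a number. Compound 2 `C=CC1=C(C(=O)Nc2ccccc2OC)C(c2ccc(F)cc2)OC1` also gives only a limit in this assay, > 100000 nM. Compound 3 `C=CC1=C(C(=O)Nc2ccc(OCC)cc2)C(c2ccc(F)cc2)OC1` likewise gives a limit in this assay, > 100000 nM. Compound 1 therefore stands nowhere in particular on the numbers shown: every value, its own included, rests at the limit of > 100000 nM in this assay, at which 3 of the 3 values shown sit. Compound 4 `C=CC1=C(C(=O)O)C(c2ccc(Cl)c(Cl)c2)OC1` differs from compound 1 by hydroxy in place of pentylamino on a carbonyl carbon. Going by the values given here, no measured step of this kind exists here, so no direction can be read off, and no change beyond the scatter is expected. The expected step that the limit leaves unreadable from compound 1 to compound 4 is essentially none. Compound 4 is thus expected to give 150000 nM, between 50000 nM and 500000 nM, most likely again only a limit.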

Compound 4, half-maximal inhibitory concentration: 10300 nM
The estimate for compound 4 lay 15-fold (1.16 log units) above the measured number, outside the stated range (below it).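

The earlier compounds shown here could not show whether the group on this carbonyl carbon matters, since all of them rested at the same limit: the limit of > 100000 nM in this assay, at which 3 of the 4 values shown sit. Compound 4 shows that it does: in this assay, hydroxy in place of pentylamino gives an at least 9.7-fold lower number from compound 1 to compound 4 (0.98 log units; beyond the scatter) on the shared core. The value of compound 1 is a limit, so this size is a floor and not an exact step.

This single swap cannot separate losing the pentyl chain from gaining hydroxy. A shorter chain such as ethylamino, or a methoxy group on the same carbonyl carbon, would help tell these apart.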